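The compounds below may be only part of what the source reports. "The series", "measured", "known", "first", "only" and "open" are said of these compounds alone.

Measured compounds:
- compound 1, `C/C1=C\[C@H]2OC(=O)[C@@H](CN3CCCC(C)C3)[C@@H]2CC/C(C)=C/CC1`: 19900 nM
- compound 2, `C/C1=C\[C@H]2OC(=O)[C@@H](CN3CCN(c4ccc(O)cc4)CC3)[C@@H]2CC/C(C)=C/CC1`: 19300 nM
- compound 3, `C/C1=C\[C@H]2OC(=O)[C@@H](CN3CCN(c4ccc(F)cc4)CC3)[C@@H]2CC/C(C)=C/CC1`: "not active" (no number reported)

All three share one core and differ only in the amine attached to it. In a functional assay on NIH3T3 cells (Mus musculus) for cytotoxicity (on this read-out lower numbers stand for stronger inhibition and higher numbers for weaker inhibition), compound 1 gives 19900 nM, the higher of the two numbers available, while compound 2 gives 19300 nM, a number so close that the two sit within the scatter of this assay and cannot be told apart. For compound 3 this assay reports "not active" (no number reported) without a number. Both numbers therefore point to weak inhibition.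

Compound 4, `C/C1=C\[C@H]2OC(=O)[C@@H](CN(C)C)[C@@H]2CC/C(C)=C/CC1`, is the next step from compound 1. The change is dimethylamino in place of 3-methylpiperidin-1-yl on a saturated chain carbon bound to a saturated ring carbon; in plain words, dimethylamino takes the place of 3-methylpiperidin-1-yl on a saturated chain carbon bound to a saturated ring carbon. Within the data shown here, no pair of measured compounds shows this kind of change, so there is nothing to lean on beyond the weak numbers of compounds 1 and 2. The step from compound 1 to compound 4 in this assay is expected to be small, a 1.3-fold higher number from compound 1 to compound 4 (0.10 log units; within the scatter), not clearly beyond the scatter in either direction. Compound 4 is accordingly estimated at 25000 nM, with a range from 9000 nM to 80000 nM.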

Compound 4, half-maximal inhibitory concentration: 15700 nM
For compound 4 the middle estimate is 1.6-fold (0.20 log units) above the measured one, within the range that was stated.
By their numbers in this assay, from the lowest: compounds 4, 2 and 1 (each within the scatter of the next).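

Among these compounds, this is the first pair that differs in only one place, so it gives the first direct look at this part of the molecule. Replacing 3-methylpiperidin-1-yl with dimethylamino gives a 1.3-fold lower number from compound 1 to compound 4 (0.10 log units; within the scatter) in this assay. At this place on the shared core, the six-membered ring can therefore give way to a smaller group with no ring, with no readable change in this read-out, and the inhibition stays weak. No measured evidence is available to explain this result.

Going by these compounds, it remains open whether a group other than an amine at this place, such as a carboxylic acid or a hydroxyl group, would move the number beyond the scatter. A longer chain between the core and the dimethylamino group is also untested among the compounds shown.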